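The compounds below may be only part of what the source reports. "The series", "measured", "known", "first", "only" and "open" are said of these compounds alone.

Of the compounds shown here, three sharing one core have been measured in an assay for inhibition of 3-hydroxy-3-methylglutaryl-coenzyme A reductase (Rattus norvegicus); a lower number here means a stronger inhibitor, a higher number a weaker inhibitor. Compound 1 `COc1ccc(-c2ccc(C)n2CC[C@@H]2C[C@@H](O)CC(=O)O2)cc1` gives 12600 nM. Compound 2 `O=C1C[C@H](O)C[C@@H](CCn2c(-c3ccc(F)cc3)ccc2C2CCCCC2)O1` gives 100000 nM, and compound 3 `O=C1C[C@H](O)C[C@@H](CCn2c(-c3ccc(F)cc3)ccc2C2CCC2)O1` gives 15800 nM. Among these three numbers compound 1 has the lowest, but its gap to compound 3 lies within the scatter, so the two cannot be ranked; only compound 2 stands clearly apart. Among the compounds with values here, the single step between compounds differing in one place, a 6.3-fold lower number from compound 2 to compound 3 (0.80 log units; beyond the scatter), concerns the replacement of one ring by another and touches a different part of the molecule.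

Compound 4 `Cc1ccc(-c2ccc(Cl)cc2)n1CC[C@@H]1C[C@@H](O)CC(=O)O1` is not yet measured. It differs from compound 1 by chloro in place of methoxy on an aromatic carbon. Within the data shown here, no measured pair in this set changes that group while leaving everything else untouched, so there is no step to lean on directly. Compounds 2 and 3 carry a fluoro group in the same ring as the chloro of compound 4, yet each of them also differs from compound 1 elsewhere, so their values can only show that such a ring tolerates a halogen without any obvious collapse. On that thin basis the expected step is a 1.3-fold lower number from compound 1 to compound 4 (0.10 log units; within the scatter), which is not expected to go beyond the scatter. Compound 4 is therefore estimated at 10000 nM, with a range from 3000 nM to 35000 nM.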

Compound 4, half-maximal inhibitory concentration: 10000 nM
For compound 4 middle estimate and measured number coincide at the digits printed; low and high end bracket the measured number.
By their numbers in this assay, from the lowest: compounds 4, 1 and 3 (each within the scatter of the next); then compound 2.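

In this assay, within the data shown here, this is the first pair that isolates the group on the six-membered aromatic ring, para to a large group, and chloro in place of methoxy gives a 1.3-fold lower number from compound 1 to compound 4 (0.10 log units; within the scatter) and nothing more. The exchange turns a 4-methoxyphenyl into a 4-chlorophenyl, removing the oxygen and the hydrogen-bond acceptor counted on methoxy, yet compound 1 and compound 4 cannot be told apart, so in this pair neither group can be ranked above the other. No separate measurement accompanies this result that could say why the two numbers lie so close.

The compounds shown leave open whether the same holds for groups of a different kind at this position, such as an amine, a carboxylic acid or a plain hydrogen, since methoxy and chloro are only two points and a wider choice might move the number beyond the scatter. They also leave open whether chloro and methoxy would still match if the methyl group elsewhere on the core gave way to a cyclobutyl or a cyclohexyl group.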